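Carbamoylmethyl for isopropyl on a shared thiazole-free core

This account rests on a few compounds, and the source may have more. Where it says the series, first, only, none or still open, it means among the compounds named here.

Compounds measured so far:
compound 1, `COc1ccc(-c2nc(CCO)sc2-c2ccc(OC)cc2)cc1`, 9%
compound 2, `COC(=O)C(C)(C)c1nc(-c2ccc(OC)cc2)c(-c2ccc(OC)cc2)s1`, 27%
compound 3, `COc1ccc(-c2nc(C(C)C)sc2-c2ccc(OC)cc2)cc1`, 6%

These three share one core and differ only in the group on one aromatic carbon. In a functional assay on the whole organism for inhibition, with Cavia porcellus as the target, at a dose of 1 mg/kg by the oral route (on this read-out higher numbers stand for a stronger effect at the one dose given and lower numbers for a weaker effect), compound 3 gives 6%, the lowest of the three numbers. Its nearest neighbour is compound 1, a step of a number 3 percentage points lower from compound 1 to compound 3 (within the scatter), which lies within the scatter; its furthest is compound 2, a step of a number 21 percentage points lower from compound 2 to compound 3 (beyond the scatter), which lies beyond it.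

Compound 4, `COc1ccc(-c2nc(CC(N)=O)sc2-c2ccc(OC)cc2)cc1`, has not yet been measured in this assay. Its structure differs from compound 3 in one place: carbamoylmethyl in place of isopropyl on an aromatic carbon.

Going by the values given here, two measured steps bear on this change. Going from compound 1 to compound 2, the step was a number 18 percentage points higher from compound 1 to compound 2 (beyond the scatter), and from compound 2 to compound 3 it was a number 21 percentage points lower from compound 2 to compound 3 (beyond the scatter). The group entering in compound 4 brings a hydrogen-bond donor and acceptor, as the group in compound 1 does, yet compound 1 itself stands within the scatter of compound 3. The only clear gain came with compound 2, whose group is not the one entering here. The expected step is therefore a number 6 percentage points higher from compound 3 to compound 4 (within the scatter), modest and uncertain in direction. Compound 4 is estimated at 12%, with a range from 2% to 30%.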

Compound 4, a percentage reported as inhibition, in the whole organism at one dose (the size of the read-out at that dose, not a potency): 39%
Beside the measured number, compound 4's estimate is 27 percentage points below it; measured number above the stated range.
By their numbers in this assay, from the lowest: compounds 3 and 1 (each within the scatter of the next); then compound 2; then compound 4.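

In this assay, the group on this aromatic carbon can carry a large part of the read-out: carbamoylmethyl in place of isopropyl gives a number 33 percentage points higher from compound 3 to compound 4 (beyond the scatter). A hydrogen-bond donor and acceptor on this position do not by themselves secure the gain, as carbamoyl in place of hydroxymethyl on the same chain carbon still gives a number 30 percentage points higher from compound 1 to compound 4 (beyond the scatter). The 1-(methoxycarbonyl)-1-methylethyl group is also not the highest-reading group at this position, with a number 12 percentage points higher from compound 2 to compound 4 (beyond the scatter).

No measurement available here accounts for the gain. Still open, from the compounds shown here alone, is which part of the carbamoylmethyl group matters, something a carboxylic acid, a dimethylated amide or a longer chain ending in the same amide could separate at this position.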